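A few compounds are considered here, and "the series" means these few. Any claim that something is new, unique, unknown or untested is made for them only; others in the source may bear on it.

Compound 1 `CCCCc1ccc(COC(=O)N[C@H]2CNC2=O)cc1` is the most potent of the three compounds measured in an assay on HEK293 cells for inhibition of N-acylethanolamine-hydrolyzing acid amidase (Homo sapiens), read by fluorescence, with stated times of 10 min and 50 min (on this read-out lower numbers stand for stronger inhibition and higher numbers for weaker inhibition), where compound 1 gives 23 nM. Compound 2 `O=C(N[C@H]1CNC1=O)OCc1ccc2c(c1)CCCC2` gives 140 nM in this assay, and compound 3 `CC(OC(=O)N[C@H]1CNC1=O)c1ccc(C2CCCCC2)cc1`, which carries a cyclohexyl group and a methyl group on the carbon next to the carbamate oxygen, gives 4470 nM. Compound 4 `O=C(N[C@H]1CNC1=O)OCc1ccc(C2CCOCC2)cc1` has not yet been measured; it differs from compound 1 by oxan-4-yl in place of butyl on an aromatic carbon. Within the data shown here, no directly comparable pair of measured compounds exists for this change, so the expectation rests on the spread of the three values. Compound 4 is expected to lose some potency, with the step from compound 1 to compound 4 estimated as a 3.0-fold higher number from compound 1 to compound 4 (0.48 log units; beyond the scatter). For compound 4 in this assay an estimate of 70 nM is given, likely within 15 nM to 350 nM.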

Compound 4, half-maximal inhibitory concentration: 1370 nM
Compound 4: middle estimate off by 20-fold (1.29 log units), on the low side; measured number above the stated range.
By their numbers in this assay, from the lowest: compound 1; then compound 2; then compound 4; then compound 3.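

Replacing butyl with oxan-4-yl on this aromatic carbon gives a 60-fold higher number from compound 1 to compound 4 (1.77 log units; beyond the scatter), a large loss of potency. Among these compounds, this is the first single-place comparison in the set, and it shows that this position does not accept every group: the swap adds a six-membered ring and a hydrogen-bond acceptor, and inhibition falls sharply. No measurement here explains the size of this loss.

Going by these compounds, whether the ring or its oxygen matters more stays open. So does how a longer chain such as hexyl, or an amine such as piperidin-4-yl, would behave here.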